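Cyclohexyloxy for propyl on a beta-lactam carbamate

The source may report more compounds than this note shows. Statements on the series, on what has been measured and on what is new or still open speak of the compounds shown alone.

Two carbamates that share one core have been measured. Compound 1 `CCCc1ccc(COC(=O)N[C@H]2CNC2=O)cc1` has the lowest number of the two: in an assay on HEK293 cells for inhibition of N-acylethanolamine-hydrolyzing acid amidase (Homo sapiens), read by fluorescence, with stated times of 10 min and 50 min (a lower number here means a stronger inhibitor, a higher number a weaker inhibitor), compound 1 gives 52 nM. Compound 2 `O=C(N[C@H]1CNC1=O)OCc1ccc2c(c1)CCCC2` is the nearest neighbour; in this assay compound 2 gives 140 nM, a higher number than compound 1, and the gap between the two lies beyond the usual scatter. Going by the values given here, no pair of measured compounds differs in only one place, so no step between measured compounds is available to guide the next move.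

Compound 3 `O=C(N[C@H]1CNC1=O)OCc1ccc(OC2CCCCC2)cc1` is not yet measured. It differs from compound 1 in one place: cyclohexyloxy in place of propyl on an aromatic carbon. Among the compounds with values here, with only two measured compounds and no single-point step to lean on, the change from compound 1 to compound 3 is expected to stay within the scatter, perhaps a little toward a lower number, so the step of a 1.3-fold lower number from compound 1 to compound 3 (0.11 log units; within the scatter) is an estimate of little change. Compound 3 is expected to give 40 nM in this assay, with a range from 12 nM to 130 nM.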

Compound 3, half-maximal inhibitory concentration: 2070 nM
Beside the measured number, compound 3's estimate is 52-fold (1.71 log units) below it, and the stated range ends below it.
By their numbers in this assay, from the lowest: compound 1; then compound 2; then compound 3.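

In this assay, the aromatic carbon para to a large group proves highly sensitive to the group it carries: cyclohexyloxy in place of propyl gives a 40-fold higher number from compound 1 to compound 3 (1.60 log units; beyond the scatter), a large step beyond the scatter, which shows that the good value of compound 1 does not carry over to every group at this position. The change is not a simple one, as propyl, with 3 heavy atoms and no ring, gives way to cyclohexyloxy, with 7 heavy atoms, a six-membered non-aromatic ring of carbon only and a hydrogen-bond acceptor, so this one step cannot show which of these differences matters. Nothing available explains why the number rises so far.

The compounds shown leave open whether the oxygen, the ring or the overall size of the new group accounts for the step, since all three change together between compound 1 and compound 3. A propoxy group would keep the chain of compound 1 and add the oxygen, whereas a cyclohexyl group would keep the ring without the oxygen, and neither is among the compounds shown.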